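The source may hold more compounds than are shown below. What is called first, only, known or untested is meant among the compounds shown, and "the series" means these compounds.

Measured so far in a physicochemical assay for solubility, in phosphate buffer, measured as thermodynamic solubility, at pH 2; on this read-out lower numbers stand for lower solubility and higher numbers for higher solubility:

- compound 1 `NC1CCN(c2nc3c(c(Nc4ccc(C(F)(F)F)cc4)n2)CCN(c2ncccc2C(F)(F)F)CC3)C1`: > 215 ug/mL (a limit)
- compound 2 `CC(C)(C)OC(=O)N1CCCC(Nc2nc3c(c(Nc4ccc(C(F)(F)F)cc4)n2)CCN(c2ncccc2C(F)(F)F)CC3)C1`: 1 ug/mL
- compound 3 `CN1CCCCC1CNc1nc2c(c(Nc3ccc(C(F)(F)F)cc3)n1)CCN(c1ncccc1C(F)(F)F)CC2`: > 277 ug/mL (a limit)

Within the data shown here, compound 3 has no exact number in this assay and stands at the limit of > 277 ug/mL in this assay, at which 1 of the 3 values shown sits, as its only reading. Compound 1 is likewise known only as a limit, at the limit of > 215 ug/mL in this assay, at which 1 of the 3 values shown sits, and no further.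

Compound 4 `FC(F)(F)c1ccc(Nc2nc(NC3CCCNC3)nc3c2CCN(c2ncccc2C(F)(F)F)CC3)cc1` has not yet been measured. It departs from compound 3 on a nitrogen on an aromatic ring, where piperidin-3-yl replaces (1-methylpiperidin-2-yl)methyl: piperidin-3-yl in place of (1-methylpiperidin-2-yl)methyl on a nitrogen on an aromatic ring is the counted difference.

Among the measured compounds shown here, the one measured step that bears on this also exchanges the group on the shared core. It is a step that the two limits leave unreadable from compound 1 to compound 3 and so offers no size to carry over. Compound 2 gives a true number of 1 ug/mL but carries a tert-butoxycarbonyl group that compound 4 lacks, so it is a poor guide here.

With no readable step to lean on, the expectation is that compound 4 stays with compounds 1 and 3, with no change beyond the scatter and no firm direction. The estimated result is an at least 1.1-fold lower number from compound 3 to compound 4 (0.04 log units; that floor lies within the scatter) and this remains an expectation only. For compound 4 the estimate is 250 ug/mL as the expected value. The expected range for compound 4 runs from 120 ug/mL to 400 ug/mL and the assay may again report only a limit.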

Compound 4, solubility: > 235 ug/mL
Compound 4: no number, only a limit; the forecaster's own chance of this, stated with the estimate: 65%; the middle value lies beyond the limit too.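

In this assay compound 4 gives > 235 ug/mL, which is a limit and not a number. Among these compounds, the step of hydrogen in place of tert-butoxycarbonyl on an amine nitrogen in a ring reads as an at least 230-fold higher number from compound 2 to compound 4 (2.37 log units; beyond the scatter), and it is the first step in this set with a readable size, which the earlier compounds did not provide. The steps linking compound 4 to compound 1 and to compound 3 cannot be read, with limits at both ends, so piperidin-3-yl in place of (1-methylpiperidin-2-yl)methyl on a nitrogen on an aromatic ring still has no measured size.

On these data alone, the true numbers of compound 1, compound 3 and compound 4 in this assay remain unknown, and so does any order among them. As far as these compounds go, it also remains open whether a methyl or an acetyl group on the ring nitrogen of the piperidin-3-yl group would leave a compound at a limit, like compound 4, or give a true number, like compound 2.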